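From 4-methylphenyl to 5-bromothiophen-2-yl on the sulfonyl sulfur

The source may report more compounds than this note shows. Statements on the series, on what has been measured and on what is new or still open speak of the compounds shown alone.

Among the measured compounds shown here, in a functional assay on MDA-MB-231 cells (Homo sapiens) for inhibition, read by sulforhodamine B assay, with a stated time of 74 h (on this read-out lower numbers stand for stronger inhibition and higher numbers for weaker inhibition), compound 1 `Cc1ccc(S(=O)(=O)N2C(=O)COC23C=CC(=O)C=C3)cc1` gives 70 nM, the lowest of the three numbers measured so far. Compound 2 `Cc1ccc(S(=O)(=O)N2C(=O)C(C)OC23C=CC(=O)C=C3)cc1` gives 1100 nM, and compound 3 `O=C1C=CC2(C=C1)OCC(=O)N2S(=O)(=O)c1ccc(C(F)(F)F)cc1` gives 2100 nM. Compound 4 `O=C1C=CC2(C=C1)OCC(=O)N2S(=O)(=O)c1ccc(Br)s1` keeps the core of compound 1 but carries 5-bromothiophen-2-yl in place of 4-methylphenyl on a sulfonyl sulfur.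

Two measured steps lead away from compound 1, and both are large. The step of a 16-fold higher number from compound 1 to compound 2 (1.20 log units; beyond the scatter) comes with methyl in place of hydrogen on a saturated ring carbon, away from the group that changes here. The step of a 30-fold higher number from compound 1 to compound 3 (1.48 log units; beyond the scatter) comes with trifluoromethyl in place of methyl on an aromatic carbon, so it bears more directly, as it also alters the group on the sulfonyl sulfur. For the measured compounds named here, no measured compound contains a thiophene or a bromine, so this evidence is indirect. Both changes raised the number, and a rise is therefore expected again, though the replacement differs from that in compound 3. The expected step is an 8.6-fold higher number from compound 1 to compound 4 (0.93 log units; beyond the scatter), probably beyond the scatter. In this assay, compound 4 is estimated at 600 nM, with an expected range from 120 nM to 3000 nM.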

Compound 4, half-maximal inhibitory concentration: > 10000 nM
Compound 4 was reported as a limit; the forecaster's own chance of this, stated with the estimate: 3%; middle value at least 16-fold (1.22 log units) away from the limit.
By their numbers in this assay, from the lowest: compound 1; then compounds 2 and 3 (each within the scatter of the next). At a limit, above all of these: compound 4.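

In this assay, compound 4 is reported only as a limit of the assay, > 10000 nM, and not as a number. The exchange on the sulfonyl sulfur gives an at least 140-fold higher number from compound 1 to compound 4 (2.15 log units; beyond the scatter), the largest step shown, so the group on this sulfur can do more than shift the read-out within the measured range: it can carry the value out of that range altogether. Among the compounds shown here, compound 3, changed on the same sulfur but keeping a six-membered aromatic ring of carbon only, still gives a number, 2100 nM, so the earlier compounds showed a loss at this position but not one of this extent.

How far compound 4 truly lies from compound 1 stays open, and the shown compounds do not separate the five-membered ring containing sulfur from the bromine, since the two enter together: the limit of > 10000 nM in this assay, at which 1 of the 4 values shown sits.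
From the compounds shown here alone, whether a thiophen-2-yl group without bromine, or a 4-bromophenyl group, would stay closer to compound 1 remains open, and so does the effect of an amine or a methoxy group on the aromatic ring attached to this sulfur.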